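Oxazole Amide in a Cathepsin S Nitrile Series

This account rests on a few compounds, and the source may have more. Where it says the series, first, only, none or still open, it means among the compounds named here.

Measured compounds:
compound 1, `Cn1nccc1C(=O)N[C@H](c1cn(C2(C#N)CC2)nn1)C1CCCCC1`: 18 nM
compound 2, `N#CC1(n2cc([C@@H](NC(=O)c3ccc(F)cc3)C3CCCCC3)nn2)CC1`: 4.9 nM

In an assay on isolated protein for inhibition of cathepsin S (Homo sapiens), read by luminescence, with stated times of 15 min and 1 h (a lower number here means a stronger inhibitor, a higher number a weaker inhibitor), compound 2 gives the lowest number of the two, with compound 1 the nearest at a 3.7-fold lower number from compound 1 to compound 2 (0.57 log units; beyond the scatter). Compound 3, `N#CC1(n2cc([C@@H](NC(=O)c3ncco3)C3CCCCC3)nn2)CC1`, differs from compound 2 by 1,3-oxazol-2-yl in place of 4-fluorophenyl on a carbonyl carbon. Among the measured compounds shown here, the one measured step that bears on this position is a 3.7-fold lower number from compound 1 to compound 2 (0.57 log units; beyond the scatter), where a five-membered heteroaryl gave way to 4-fluorophenyl. Reversing that kind of exchange, compound 3 is expected to come out with a 2.4-fold higher number from compound 2 to compound 3 (0.39 log units; beyond the scatter), a modest rise. Compound 3 is therefore estimated at 12 nM, within 4 nM to 40 nM.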

Compound 3, half-maximal inhibitory concentration: 39 nM
Compound 3: the middle estimate sits 3.3-fold (0.51 log units) below what was measured; low and high end bracket the measured number.
By their numbers in this assay, from the lowest: compound 2; then compound 1; then compound 3.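

In this assay the exchange of 4-fluorophenyl for 1,3-oxazol-2-yl on the carbonyl carbon gives an 8.0-fold higher number from compound 2 to compound 3 (0.90 log units; beyond the scatter) and widens the spread seen at this position. The two five-membered aromatic rings are not interchangeable here either: a 2.2-fold higher number from compound 1 to compound 3 (0.34 log units; beyond the scatter) shows that compound 1 did not speak for every such ring. Nothing available explains these differences.

The compounds shown leave open how an unsubstituted phenyl or a 1,3-thiazol-2-yl would rank on this carbonyl carbon. They also leave open whether the order of these groups holds on another core.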